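This account rests on a few compounds, and the source may have more. Where it says the series, first, only, none or still open, it means among the compounds named here.

In a functional assay on RAW264.7 cells (Mus musculus) for inhibition, read by Griess assay, with stated times of 1 h and 24 h (a lower number here means a stronger inhibitor, a higher number a weaker inhibitor), compound 1 `COc1cc(NC(=O)c2cccc(-c3cc(=O)c4c(OC)c(OC)c(OC)cc4o3)c2)cc(OC)c1OC` gives 2750 nM. Compound 2 `COc1ccccc1NC(=O)c1cccc(-c2cc(=O)c3c(O)c(OC)c(OC)cc3o2)c1` is recorded as "not determined" (no result reported). Compound 3 `COc1cccc(NC(=O)c2cccc(-c3cc(=O)c4c(O)c(OC)c(OC)cc4o3)c2)c1` is likewise recorded as "not determined" (no result reported), so it stands without a number and offers no measured starting point. Compound 4 `COc1cc(NC(=O)c2cccc(-c3cc(=O)c4c(O)c(OC)c(OC)cc4o3)c2)cc(OC)c1OC` differs from compound 3 in one place, with 3,4,5-trimethoxyphenyl in place of 3-methoxyphenyl on an amide-type nitrogen. For the measured compounds named here, no measured step shows what such a change does in this assay. Going by the values given here, the only available number is that of compound 1, at 2750 nM, so the expectation is a result within the usual scatter of it, with no direction favoured. Compound 4 is expected at 2500 nM, within an estimated range of 800 nM to 8000 nM.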

Compound 4, half-maximal inhibitory concentration: 2110 nM
Estimate against measurement, compound 4: 1.2-fold (0.07 log units) above, within the range that was stated.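

In this assay, for the compounds shown here, the first readable change on the shared core, hydrogen in place of methyl on an oxygen on an aromatic ring, gives a 1.3-fold lower number from compound 1 to compound 4 (0.12 log units; within the scatter), so the methyl on that oxygen can go without a measurable change in this assay. No measurement at hand offers an explanation for this result. Compound 3 has no number, so the swap of 3-methoxyphenyl for 3,4,5-trimethoxyphenyl on the amide-type nitrogen cannot be read. As far as these compounds go, what an ethyl group on that oxygen, or an amine in place of it, would do remains open.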